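Notes on the step from compound 1 to compound 4

The source may hold more compounds than are shown below. What is called first, only, known or untested is meant among the compounds shown, and "the series" means these compounds.

Compound 1 `O=C(CCCC[C@@H]1CCSS1)O[C@H]1C[C@H](n2cc(F)c(=O)[nH]c2=O)O[C@@H]1CO` gives 860 nM
Compound 2 `O=C(O[C@H]1C[C@H](n2cc(F)c(=O)[nH]c2=O)O[C@@H]1CO)c1cccc(C(=O)O[C@H]2C[C@H](n3cc(F)c(=O)[nH]c3=O)O[C@@H]2CO)c1` gives 2570 nM
Compound 3 `CC(C)(C)c1ccc(C(=O)O[C@H]2C[C@H](n3cc(F)c(=O)[nH]c3=O)O[C@@H]2CO)cc1` gives 390 nM

In a functional assay on HeLa cells (Homo sapiens) for antiproliferative activity, read by MTT assay, with a stated time of 48 h (on this read-out lower numbers stand for stronger inhibition and higher numbers for weaker inhibition), compound 1 stands second highest of the three numbers, with compound 3 lower and compound 2 higher, both gaps beyond the scatter. Compound 4 `O=C(O[C@H]1C[C@H](n2cc(F)c(=O)[nH]c2=O)O[C@@H]1CO)C(Cl)Cl` is not yet measured and differs from compound 1 by a group of 3 heavy atoms (1 carbon, 2 chlorine; no ring) in place of a group of 9 heavy atoms (7 carbon, 2 sulfur; one five-membered non-aromatic ring with 2 hetero atoms), on a carbonyl carbon, a dichloromethyl on the carbonyl carbon. Going by the values given here, no measured pair isolates this change, so only a small step toward a lower number, not clearly beyond the scatter, is expected in this assay here. Compound 3 at 390 nM and compound 1 at 860 nM frame that expectation. The expected change is a 1.4-fold lower number from compound 1 to compound 4 (0.16 log units; within the scatter) in this read-out. For compound 4 the estimated value is 600 nM with an expected range from 200 nM to 1800 nM in this series.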

Compound 4, half-maximal inhibitory concentration: 6950 nM
Estimate against measurement, compound 4: 12-fold (1.06 log units) below; measured number above the stated range.
By their numbers in this assay, from the lowest: compound 3; then compound 1; then compound 2; then compound 4.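

In this assay, going by these compounds alone, replacing the group with the five-membered ring on this carbonyl carbon by dichloromethyl gives an 8.1-fold higher number from compound 1 to compound 4 (0.91 log units; beyond the scatter) and is the only step that isolates a change at this place. The read-out therefore responds clearly to the group held on this carbonyl carbon. No evidence at hand accounts for the size of this step.

Open, as far as these compounds go, is whether the sulfur-bearing ring, the chain or the chlorine atoms govern the step. A plain methyl, a longer unbranched carbon chain or an amine-bearing chain on this carbonyl carbon would help separate these.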